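A pyridinyl swap in a weakly binding series

The source may hold more compounds than are shown below. What is called first, only, known or untested is meant among the compounds shown, and "the series" means these compounds.

Measured so far:
compound 1, `COc1cccc(C(Nc2ccc(C)cc2Cl)C(=O)CCc2ccncc2)c1`: > 10000 nM
compound 2, `O=C(CCc1ccncc1)C(Nc1ccccc1Cl)c1ccccc1Br`: 7330 nM
compound 3, `Cc1ccc(NC(C(=O)CCc2ccccn2)c2ccccc2Br)c(Cl)c1`: > 10000 nM

All three were tested in an assay on isolated protein for binding affinity to corticotropin-releasing factor receptor 1 (Homo sapiens); on this read-out lower numbers stand for stronger inhibition and higher numbers for weaker inhibition. Among the compounds with values here, compound 2 is the only one that gives a number, 7330 nM. For compound 3 the value > 10000 nM is a limit of the assay, not a number. That limit is where two of the three values sit (the limit of > 10000 nM in this assay, at which 2 of the 3 values shown sit). Compound 4, `Cc1ccc(NC(C(=O)CCc2cccnc2)c2ccccc2Br)c(Cl)c1`, has not yet been measured; it differs from compound 3 by pyridin-3-yl in place of pyridin-2-yl on a saturated chain carbon, two bonds along the chain from a carbonyl carbon. Within the data shown here, no measured pair shows what this change does, and the series as a whole binds weakly. The step from compound 3 to compound 4 is therefore expected to be small, a number no higher from compound 3 to compound 4 (the limit leaves the size open), with a fair chance of again reaching only the limit. Compound 4 is estimated at 10000 nM, in the range 3000 nM to 30000 nM.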

Compound 4, inhibition constant: > 10000 nM
Compound 4: no number, only a limit; the forecaster's own chance of this, stated with the estimate: 60%; the middle value sits exactly at the limit.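

Compound 3 and compound 4 both end at a limit of the assay rather than a number, so no step between them can be read: the limit of > 10000 nM in this assay, at which 3 of the 4 values shown sit.

From the compounds shown here alone, whether pyridin-3-yl in place of pyridin-2-yl changes binding at all stays open.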